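Ortho substituent swap on the phenyl arm of the series

The source may hold more compounds than are shown below. What is called first, only, known or untested is meant among the compounds shown, and "the series" means these compounds.

For the measured compounds named here, compound 2 `COc1ccccc1-c1cn2ccnc2c(-c2ccc3ncn(C4CCCCC4)c3c2)n1` holds the lowest of the two numbers so far in a functional assay on SK-MEL-5 cells (Homo sapiens) for inhibition, read by sulforhodamine B assay, with a stated time of 48 h, tested at 10 uM (on this read-out lower numbers stand for less inhibition and higher numbers for more inhibition at the one concentration tested (going by the name of the read-out)), where compound 2 gives 8.94%. Going by the values given here, its nearest neighbour, compound 1 `Brc1ccc(-c2cn3ccnc3c(-c3ccc4ncn(C5CCCCC5)c4c3)n2)cc1`, gives 23.6% in this assay, and the one measured step, a number 14.7 percentage points lower from compound 1 to compound 2 (beyond the scatter), concerns a 2-methoxyphenyl in place of a 4-bromophenyl. Compound 3 `Fc1ccccc1-c1cn2ccnc2c(-c2ccc3ncn(C4CCCCC4)c3c2)n1` differs from compound 2 only by fluoro in place of methoxy on an aromatic carbon, the position being ortho to a large group. Among the compounds with values here, no measured step exchanges methoxy for fluoro, so the single step on record bears only loosely on this change: it shows that the group on the phenyl ring can move this read-out modestly, nothing more. For compound 3 a small step is expected, a number 5.1 percentage points higher from compound 2 to compound 3 (within the scatter), not clearly beyond the scatter. Compound 3 is therefore estimated at 14% in this assay, within a range from 0% to 30%.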

Compound 3, a percentage reported as inhibition, at one concentration (the size of the read-out at that concentration, not a potency): 6.5%
The estimate for compound 3 lay 7.5 percentage points above the measured number, within the range that was stated.
By their numbers in this assay, from the lowest: compounds 3 and 2 (each within the scatter of the next); then compound 1.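

In this assay the exchange of methoxy for fluoro, ortho to a large group, gives a number 2.4 percentage points lower from compound 2 to compound 3 (within the scatter) and so does not separate the two compounds on this read-out, even with one heavy atom and one hydrogen-bond acceptor fewer in the entering group. The second step, 2-fluorophenyl in place of 4-bromophenyl, gives a number 17.1 percentage points lower from compound 1 to compound 3 (beyond the scatter) and puts compound 3 on the same side of compound 1 as compound 2, so two different groups at this place now stand apart from compound 1. The data at hand give no reason for either step.

From the compounds shown here alone, both steps from compound 1 change the group and its place on the ring together, so the share of each stays open. Going by these compounds, whether an amine or a carboxylic acid at this place would shift the read-out beyond the scatter also stays open.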